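A few compounds are considered here, and "the series" means these few. Any claim that something is new, unique, unknown or untested is made for them only; others in the source may bear on it.

Measured so far:
Compound 1, `COc1ccc2c(=O)c(/C=C/C(=O)Nc3ccccc3OC)coc2c1`, in a functional assay on HeLa cells (Homo sapiens) for inhibition, read by MTT assay, with a stated time of 48 h (on this read-out higher numbers stand for weaker inhibition and lower numbers for stronger inhibition), gives > 100000 nM, which is a limit of the assay and not a number.
Compound 2, `COc1ccc2c(=O)c(/C=C/C(=O)NCc3ccc(C)cc3)coc2c1`, in this assay gives > 100000 nM, likewise a limit of the assay.

Compound 2 therefore stands at the edge of what this assay resolves: both measured values sit at the limit of > 100000 nM in this assay, at which 2 of the 2 values shown sit, so no number is known for either compound. Among the measured compounds shown here, the single measured step, a step that the two limits leave unreadable from compound 1 to compound 2, runs between two limits and carries no readable size or direction. Compound 3, `COc1ccc2c(=O)c(/C=C/C(=O)Nc3ccccc3C)coc2c1`, differs from compound 2 by 2-methylphenyl in place of 4-methylbenzyl on an amide-type nitrogen. For the measured compounds named here, no measured step bears readably on this change, and nothing in the two limits points to movement beyond the scatter in either direction, so the step of a number no higher from compound 2 to compound 3 (the limit leaves the size open) is expected to remain unreadable in the same way. Compound 3 is accordingly estimated at 100000 nM, between 30000 nM and 300000 nM, and is most likely to be reported only as a limit.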

Compound 3, half-maximal inhibitory concentration: 7270 nM
Beside the measured number, compound 3's estimate is 14-fold (1.14 log units) above it; measured number outside the range, below it.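

In this assay the place on the amide nitrogen proves able to carry a readable change: an at least 13-fold lower number from compound 2 to compound 3 (1.13 log units; beyond the scatter) comes with 2-methylphenyl in place of 4-methylbenzyl. The group on the aromatic carbon matters as well: an at least 13-fold lower number from compound 1 to compound 3 (1.13 log units; beyond the scatter) comes with methyl in place of methoxy, so a phenyl group on the amide nitrogen does not by itself give a measurable number. Among these three compounds, only compound 3 gives a number, and the other two remain at the edge of what the assay resolves: the limit of > 100000 nM in this assay, at which 2 of the 3 values shown sit.

From the compounds shown here alone, both steps start from a limit, and their full size stays open. Going by these compounds, what an ethyl group, a chlorine atom or an amine on that aromatic carbon would give also remains open, as does the outcome for an unsubstituted phenyl group on the amide nitrogen.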